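The compounds below may be only part of what the source reports. "The series", "measured", "known", "first", "only" and "open" are said of these compounds alone.

Measured compounds:
compound 1, `CC1(C)C(=O)NC(c2ccc(N)cc2)c2ccccc21` — 240 mg/kg
compound 2, `CC1(C)C(=O)NC(c2ccccc2N)c2ccccc21` — > 1000 mg/kg
compound 3, `CCCNCC(=O)Nc1ccc(C2NC(=O)C(C)c3ccccc32)cc1` — 340 mg/kg

In a toxicity assay on the whole organism with Mus musculus as the target, in the rotarod test (a higher number here means that more compound is needed for the effect, a lower number that less compound is needed), compound 1 gives 240 mg/kg, the lowest of the two numbers recorded. The nearest number belongs to compound 3, which gives 340 mg/kg; that gap lies within the usual scatter, so the two are read as alike. For compound 2 this assay reports only a limit, > 1000 mg/kg, and no number.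

Compound 4, `CCCCNCC(=O)Nc1ccc(C2NC(=O)C(C)(C)c3ccccc32)cc1`, has not yet been measured. It differs from compound 1 in one place: ((butylamino)methyl)carbonyl in place of hydrogen on a nitrogen on an aromatic ring. Going by the values given here, no pair of measured compounds differs by exactly this change, so its effect cannot be read off directly. Still, compound 3 already carries a closely related side chain and sits alongside compound 1, so a step beyond the scatter is not expected in either direction. Compound 4 is expected to give 320 mg/kg, with a likely range from 150 mg/kg to 700 mg/kg. The expected step is a 1.3-fold higher number from compound 1 to compound 4 (0.12 log units; within the scatter), nothing beyond the scatter, because compound 3 gives 340 mg/kg while carrying a closely related side chain.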

Compound 4, dose for half-maximal effect: 335 mg/kg
Compound 4: middle estimate off by 1.0-fold (0.02 log units), on the low side; the measured number falls inside the stated range.
By their numbers in this assay, from the lowest: compounds 1, 4 and 3 (each within the scatter of the next). At a limit, above all of these: compound 2.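

Compound 1's free amino group on the aromatic ring can take ((butylamino)methyl)carbonyl without a clear shift in this assay: the change gives a 1.4-fold higher number from compound 1 to compound 4 (0.14 log units; within the scatter). Going by these compounds alone, this is the first direct reading of this change at this position, since the earlier compounds included no pair differing in one place. The result shows only that this one chain makes no difference beyond the scatter in this assay, and no measurement shown explains why the step is so small.

As far as these compounds go, it remains open whether an acetyl group, a longer chain such as octylamino in place of butylamino, or a chain ending in a carboxylic acid would also leave the number within the scatter. From the compounds shown here alone, the effect of lengthening the chain by itself also remains open, as compound 3 and compound 4 differ in more than one place.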